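This account rests on a few compounds, and the source may have more. Where it says the series, first, only, none or still open, it means among the compounds named here.

Three compounds with a shared core have been examined in a functional assay on HEK293 cells for agonist activity at D(4) dopamine receptor (Homo sapiens), read by FLIPR; a lower number here means a smaller maximal response, a higher number a larger maximal response. Compound 1 `Cc1cccc(C(=O)NCN2CCC(c3ccccn3)CC2)c1` gives 67% in this assay. Compound 2 `Cc1ccc(C(=O)NCN2CCC(c3cccc[n+]3[O-])CC2)cc1C` gives 65%, and compound 3 `Cc1cccc(NC(=O)CN2CCC(c3ccc(O)cc3)CC2)c1` gives 60%. The three values lie close together: the gap from compound 2 to compound 1 and the gap from compound 2 to compound 3 both fall within the usual scatter of this assay, so compound 2 stands among a group of essentially indistinguishable values, and none of the three can be called the largest or smallest response. No pair of these compounds differs in a single place, so no isolated structural step can be read from the measured set.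

Compound 4 `O=C(NCN1CCC(c2cccc[n+]2[O-])CC1)c1cc(Cl)cc(Cl)c1` is the next compound of interest. It differs from compound 2 in one place: 3,5-dichlorophenyl in place of 3,4-dimethylphenyl on a carbonyl carbon. Going by the values given here, no measured pair shows what such an exchange does here, so the expectation rests on the narrow spread seen across compounds 1, 2 and 3. The step from compound 2 to compound 4 is estimated to be a number 5 percentage points lower from compound 2 to compound 4 (within the scatter), small and not clearly beyond the scatter. For compound 4 the expected value in this assay is therefore 60%, within a range from 40% to 80%.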

Compound 4, largest response reached (reported as efficacy), in percent of the reference or control that the assay uses: 64%
Estimate against measurement, compound 4: 4 percentage points below, within the range that was stated.
By their numbers in this assay, from the lowest: compounds 3, 4, 2 and 1 (each within the scatter of the next).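

Going by these compounds alone, compound 2 and compound 4 form the first pair here that differs in one place, so the group on the carbonyl carbon can now be read directly. In this assay, putting 3,5-dichlorophenyl in place of 3,4-dimethylphenyl gives a number 1 percentage points lower from compound 2 to compound 4 (within the scatter), so this one exchange leaves the maximal response indistinguishable, although this single pair cannot show how other groups would behave at this position. No measured information is available to explain this result.

Going by these compounds, whether the same exchange would give a similar result on the core of compound 1 or compound 3 remains open. Also open, on these data alone, is what a carboxylic acid, an amine or a longer alkyl chain would give in place of these substituted phenyl groups on the carbonyl carbon.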